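This account rests on a few compounds, and the source may have more. Where it says the series, first, only, none or still open, it means among the compounds named here.

Of the compounds shown here, two of a shared core have so far been measured in an assay on isolated protein for inhibition of histone deacetylase 8 (Homo sapiens), with a stated time of 1 h; on this read-out higher numbers stand for weaker inhibition and lower numbers for stronger inhibition. Compound 1 `CCOc1ccc2nc(NC(=O)COc3ccc4cc(/C=C5/SC(=O)NC5=O)ccc4c3)sc2c1` gives 17000 nM in this assay. Compound 2 `O=C(COc1ccc2cc(/C=C3/SC(=O)NC3=O)ccc2c1)Nc1ccc([N+](=O)[O-])cc1` gives 4000 nM in this assay, the lower of the two numbers, so that compound 2 stands as the stronger inhibitor of the pair, with compound 1 clearly behind it.

The next compound, compound 3 `Cc1cccc(NC(=O)COc2ccc3cc(/C=C4/SC(=O)NC4=O)ccc3c2)n1`, carries 6-methylpyridin-2-yl in place of 4-nitrophenyl on an amide-type nitrogen. Within the data shown here, nothing among the measured compounds shows how this assay responds to a ring of this kind at that position, so the expectation rests on the spread already seen between compound 1 and compound 2. The step from compound 2 to compound 3 is expected to run toward a higher number, a 2.0-fold higher number from compound 2 to compound 3 (0.30 log units; within the scatter), though it may also stay within the scatter. For compound 3 the estimate in this assay is 8000 nM, between 2500 nM and 25000 nM.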

Compound 3, half-maximal inhibitory concentration: 7500 nM
Estimate against measurement, compound 3: 1.1-fold (0.03 log units) above, and the stated range covers the measured number.
By their numbers in this assay, from the lowest: compounds 2 and 3 (each within the scatter of the next); then compound 1.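

In this assay, putting 6-methylpyridin-2-yl in place of 4-nitrophenyl on the amide-type nitrogen gives a 1.9-fold higher number from compound 2 to compound 3 (0.27 log units; within the scatter) and so leaves the read-out unmoved beyond normal repeat variation. This position therefore accepts a six-membered aromatic ring with a hetero atom as well as one of carbon only, and the loss of the nitro group leaves no mark that can be told from scatter. Nothing measured here offers an explanation for this match between the two groups.

Going by these compounds, because the ring nitrogen, the methyl and the nitro group all change in one step, their separate contributions remain unknown. Also open, on these data alone, is how the assay would respond to plain pyridin-2-yl, to a 4-aminophenyl group or to a 4-carboxyphenyl group at this position.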